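Amide aryl swap on the ethylpiperazinyl quinoline series

The source may report more compounds than this note shows. Statements on the series, on what has been measured and on what is new or still open speak of the compounds shown alone.

The series shares a quinoline-type core with an amide on one side and a cyclic or dialkyl amine on the other. Compound 1 `CCN1CCN(c2cc(C)c3cc(NC(=O)c4cccnc4)ccc3n2)CC1` carries a pyridin-3-yl amide and, in a functional assay on MCF7 cells (Homo sapiens) for antiproliferative activity, read by MTT assay, with a stated time of 72 h (a higher number here means a weaker inhibitor, a lower number a stronger inhibitor), compound 1 gives 26600 nM. Compound 2 `Cc1cc(N2CCCC2)nc2ccc(NC(=O)c3ccc(Cl)c(Cl)c3)cc12` gives 26300 nM and compound 3 `Cc1cc(N(C)C)nc2ccc(NC(=O)c3ccc(Cl)c(Cl)c3)cc12` gives 33300 nM; all three numbers sit within the scatter of one another, so compound 1 stands among them without any separation that can be read as an order.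

Compound 4 `CCN1CCN(c2cc(C)c3cc(NC(=O)c4cc5ccccc5[nH]4)ccc3n2)CC1` differs from compound 1 only at the amide: 1H-indol-2-yl in place of pyridin-3-yl on a carbonyl carbon. Among the measured compounds shown here, the single measured step, a 1.3-fold higher number from compound 2 to compound 3 (0.10 log units; within the scatter), concerns the amine side and lies within the scatter; it does not bear on a change at the carbonyl carbon. For the measured compounds named here, no measured step informs the amide change, so the expectation rests on compound 1 alone, with a wide range. Compound 4 is estimated at 15000 nM (range 3000 nM to 60000 nM), meaning an expected step of a 1.8-fold lower number from compound 1 to compound 4 (0.25 log units; within the scatter) that cannot be placed beyond the scatter with confidence.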

Compound 4, half-maximal inhibitory concentration: 2950 nM
Beside the measured number, compound 4's estimate is 5.1-fold (0.71 log units) above it; measured number below the stated range.
By their numbers in this assay, from the lowest: compound 4; then compounds 2, 1 and 3 (each within the scatter of the next).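

In this assay, among the compounds shown here, the amide position proves responsive: a 9.0-fold lower number from compound 1 to compound 4 (0.96 log units; beyond the scatter) is the only step beyond the scatter. The earlier step on the amine side stayed within the scatter, so the group on the carbonyl carbon is the one place shown where a single change separates two compounds. 1H-indol-2-yl differs from pyridin-3-yl in size, ring make-up and hydrogen-bond donor and acceptor counts, and no available evidence assigns the step to any one of these differences.

Open, on these data alone, is whether the step depends on the indole ring hydrogen, which a 1-methylindol-2-yl or benzofuran-2-yl amide would test. Also open, as far as these compounds go, is whether 1H-indol-2-yl gives a similar step with pyrrolidin-1-yl or dimethylamino in place of the ethylpiperazinyl group.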